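A few compounds are considered here, and "the series" means these few. Any claim that something is new, unique, unknown or untested is made for them only; others in the source may bear on it.

Two measured compounds share one core. Compound 1 `Cc1nn(-c2ncnc3nc[nH]c23)c2c1C(OCc1ccc(C#N)cc1)CC(=O)N2` gives 60 nM in a functional assay on HEK293 cells for agonist activity at G-protein coupled receptor 39 (Homo sapiens), read by scintillation proximity assay and inositol phosphate accumulation, with a stated time of 75 min; on this read-out lower numbers stand for an effect already at smaller amounts and higher numbers for an effect only at larger amounts of compound. Compound 2 `Cc1nn(-c2ncnc3nc[nH]c23)c2c1C(NC(=O)c1ccccc1)CC(=O)N2` gives 158 nM in this assay and stands highest of the two numbers, since a 2.6-fold higher number from compound 1 to compound 2 (0.42 log units; beyond the scatter). Compound 3 `Cc1nn(-c2ncnc3nc[nH]c23)c2c1C(OC(=O)c1ccc(F)cc1)CC(=O)N2` is not yet measured; it differs from compound 2 by ((4-fluorophenyl)carbonyl)oxy in place of benzamido on a saturated ring carbon. Within the data shown here, the only measured step that bears on this change is the one between those two compounds, and it was modest. For compound 3 a step of a 1.6-fold lower number from compound 2 to compound 3 (0.20 log units; within the scatter) is expected, placing it near the other two. Compound 3 is therefore estimated at 100 nM, within 30 nM to 400 nM.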

Compound 3, half-maximal effective concentration: 245 nM
Beside the measured number, compound 3's estimate is 2.5-fold (0.39 log units) below it; low and high end bracket the measured number.
By their numbers in this assay, from the lowest: compound 1; then compounds 2 and 3 (each within the scatter of the next).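

Putting ((4-fluorophenyl)carbonyl)oxy in place of benzamido on this saturated ring carbon gives a 1.6-fold higher number from compound 2 to compound 3 (0.19 log units; within the scatter) in this assay, so here the read-out does not separate the two groups, even though the amide hydrogen is gone. With the oxygen kept on that carbon, (4-fluorophenyl)carbonyl in place of 4-cyanobenzyl gives a 4.1-fold higher number from compound 1 to compound 3 (0.61 log units; beyond the scatter), so the group on that oxygen can shift the number. Nothing available explains either step. Compound 3 changes the linking atoms and adds fluorine together, leaving their separate contributions unknown. From the compounds shown here alone, how an amine or a carboxylic acid on this carbon would read also remains open.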